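Chalcone anilides: thiophene-to-phenyl swap on the amide

The compounds below may be only part of what the source reports. "The series", "measured", "known", "first", "only" and "open" are said of these compounds alone.

Measured so far:
compound 1, `Nc1ccc(C(=O)/C=C/c2ccccc2)cc1`, 35000 nM
compound 2, `O=C(/C=C/c1ccccc1)c1ccc(NC(=O)c2cccs2)cc1`, 28000 nM

Among the measured compounds shown here, in a functional assay on HT-29 cells (Homo sapiens) for cytotoxicity, read by resazurin assay, with a stated time of 48 h (on this read-out lower numbers stand for an effect already at smaller amounts and higher numbers for an effect only at larger amounts of compound), compound 2 gives the lowest of the two numbers, and its only neighbour is compound 1, whose value lies within the scatter of it: a 1.3-fold lower number from compound 1 to compound 2 (0.10 log units; within the scatter). That step, (thiophen-2-yl)carbonyl in place of hydrogen on a nitrogen on an aromatic ring, is the only one measured and shows that building out the amide did not move the read-out beyond the scatter.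

Compound 3, `O=C(/C=C/c1ccccc1)c1ccc(NC(=O)c2ccccc2)cc1`, differs from compound 2 by phenyl in place of thiophen-2-yl on a carbonyl carbon. For the measured compounds named here, no measured step touches this exchange on the carbonyl carbon, so only the flatness of the series so far can guide it.

The expectation is therefore a step of no change at the digits printed from compound 2 to compound 3 (within the scatter), none beyond the scatter. Compound 3 is estimated at 28000 nM in this assay, with a range from 12000 nM to 65000 nM.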

Compound 3, half-maximal effective concentration: 36000 nM
Estimate against measurement, compound 3: 1.3-fold (0.11 log units) below, within the range that was stated.
By their numbers in this assay, from the lowest: compounds 2, 1 and 3 (each within the scatter of the next).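

In this assay, phenyl in place of thiophen-2-yl on the carbonyl carbon gives a 1.3-fold higher number from compound 2 to compound 3 (0.11 log units; within the scatter) and so does not separate the two aromatic rings at this position, where earlier only the thiophen-2-yl amide had been compared with the parent. The benzoyl group on the nitrogen also stays within the scatter of hydrogen there, with a 1.0-fold higher number from compound 1 to compound 3 (0.01 log units; within the scatter) as the step, so two different aromatic acyl groups now read alike against compound 1. Nothing on hand accounts for this flat result.

Open, on these data alone, is whether a non-aromatic group on the carbonyl carbon, such as a longer alkyl chain, would leave the read-out within the scatter. Also open, as far as these compounds go, is the effect of an amine or a carboxylic acid on the phenyl of the benzoyl group.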